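An Added Methyl on the Amide of Compound 1

A few compounds are considered here, and "the series" means these few. Any claim that something is new, unique, unknown or untested is made for them only; others in the source may bear on it.

Compound 1 (`CCC1C(=O)N(C)c2cnc(-n3ccc4cc(C(=O)NC)ccc43)nc2N1c1ccn(C)n1`) gives 35700 nM in a functional assay on NCI-H1975 cells (Homo sapiens) for antiproliferative activity, read by CCK-8 assay, with a stated time of 72 h (on this read-out higher numbers stand for weaker inhibition of growth and lower numbers for stronger inhibition of growth), and holds the highest number of the three measured compounds. Compound 2 (`CC[C@@H]1C(=O)N(C)c2cnc(Nc3ccc(S(=O)(=O)Nc4ccccc4)cc3)nc2N1C1CCCC1`) gives 6000 nM on the same read-out, and compound 3 (`CC[C@@H]1C(=O)N(C)c2cnc(Nc3ccc(S(=O)(=O)NCCCO)cc3)nc2N1C1CCCC1`) gives 2140 nM there as well. Compound 4 (`CCNC(=O)c1ccc2c(ccn2-c2ncc3c(n2)N(c2ccn(C)n2)C(CC)C(=O)N3C)c1`) has not yet been measured. It differs from compound 1 by one change (methyl in place of hydrogen on a saturated chain carbon bound to an amide-type nitrogen): methyl in place of hydrogen on a saturated chain carbon bound to an amide-type nitrogen, turning methylcarbamoyl into ethylcarbamoyl.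

For the measured compounds named here, no measured step adds a methyl at this place. Going by the values given here, the only measured single change is a 2.8-fold lower number from compound 2 to compound 3 (0.45 log units; beyond the scatter) and comes from 3-hydroxypropyl in place of phenyl on a sulfonamide nitrogen. That modest step lies elsewhere and bears only loosely on this one, so it gives no direction. The estimated step is a 1.2-fold lower number from compound 1 to compound 4 (0.08 log units; within the scatter) and is expected to stay within the scatter. In this assay compound 4 is expected at 30000 nM in a range running from 14000 nM up to 65000 nM on repeat measurement.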

Compound 4, concentration for 50% growth inhibition: "not active" (no number reported)
No number was reported for compound 4, and the estimate cannot be compared.
By their numbers in this assay, from the lowest: compound 3; then compound 2; then compound 1.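

For the compounds shown here, with no number reported for compound 4, no step from compound 1 to compound 4 can be read in this assay. Nothing available bears on this result. The compounds shown leave open what size of effect ethylcarbamoyl in place of methylcarbamoyl has on growth inhibition.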